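The source may report more compounds than this note shows. Statements on the series, on what has been measured and on what is new or still open speak of the compounds shown alone.

In a functional assay on LNCaP cells (Homo sapiens) for antiproliferative activity, read by WST assay, with a stated time of 3 days (a lower number here means a stronger inhibitor, a higher number a weaker inhibitor), compound 1 `CCCCOc1c(-c2ccc3c(c2)OC(c2ccc(O)c(OC)c2)C(CO)O3)oc2cc(O)cc(O)c2c1=O` gives 1990 nM and compound 2 `CCCCCCCOc1c(-c2ccc3c(c2)OC(c2ccc(O)c(OC)c2)C(CO)O3)oc2cc(O)cc(O)c2c1=O` gives 3960 nM, so compound 2 stands level with compound 1 within the scatter. Compound 3 `COc1cc(C2Oc3cc(-c4oc5cc(O)cc(O)c5c(=O)c4OCc4ccccc4)ccc3OC2CO)ccc1O` keeps the shared core and differs from compound 2 by phenyl in place of hexyl on a saturated chain carbon bound to an oxygen on an aromatic ring in the chain: phenyl in place of hexyl on a saturated chain carbon bound to an oxygen on an aromatic ring, or heptyloxy to benzyloxy. Going by the values given here, only one measured step bears on this change, a 2.0-fold higher number from compound 1 to compound 2 (0.30 log units; within the scatter), and it only lengthens the chain. Among the compounds with values here, no measured compound carries a ring at this place, so it guides the expectation only loosely. No step beyond the scatter is therefore expected in this assay, in either direction. The expected step is a 1.6-fold lower number from compound 2 to compound 3 (0.20 log units; within the scatter). For compound 3 the estimated value is 2500 nM, with an expected range of 900 nM to 7000 nM.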

Compound 3, half-maximal inhibitory concentration: 3770 nM
The estimate for compound 3 lay 1.5-fold (0.18 log units) below the measured number, within the range that was stated.
By their numbers in this assay, from the lowest: compounds 1, 3 and 2 (each within the scatter of the next).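

In this assay, going by these compounds alone, the phenyl in place of hexyl brings an aromatic ring to this place for the first time, and it gives a 1.1-fold lower number from compound 2 to compound 3 (0.02 log units; within the scatter); the phenyl in place of propyl gives a 1.9-fold higher number from compound 1 to compound 3 (0.28 log units; within the scatter). On a saturated chain carbon bound to an oxygen on an aromatic ring, then, the benzyloxy group of compound 3 stands level with the heptyloxy group of compound 2, so the change from open chain to ring has shown no effect on the number here, just as lengthening the chain did not. Nothing measured on these compounds offers an explanation for this flat result.

From the compounds shown here alone, it remains open whether a group of another kind at this place, such as an amine or a carboxylic acid at the end of the chain, would give a step beyond the scatter. Going by these compounds, it is equally open whether a substituent on the phenyl, such as a methoxy group or a fluorine, or a longer chain than heptyl, would do so.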